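This account rests on a few compounds, and the source may have more. Where it says the series, first, only, none or still open, it means among the compounds named here.

In an ADME assay on CEM-SS cells (Homo sapiens) for cytotoxicity, read by XTT assay (on this read-out lower numbers stand for higher toxicity in this test and higher numbers for lower toxicity in this test), compound 1 (`CN(O)C(=O)c1cc2ccn(Cc3ccc(F)cc3)c2cn1`) gives 135000 nM as a plain number. Compound 2 (`CN1CCN(Cc2cn(Cc3ccc(F)cc3)c3cnc(C(=O)N(C)O)cc23)CC1`) reads > 224000 nM and this is a limit of the assay. Compound 3 (`COCCOCc1cn(Cc2ccc(F)cc2)c2cnc(C(=O)N(C)O)cc12`) reads > 100000 nM and this too is a limit, so compound 3 stands without an exact number. Compound 4 (`CN(O)C(=O)c1cc2c(COC3CCOCC3)cn(Cc3ccc(F)cc3)c2cn1`) departs from it in one place: oxan-4-yl in place of 2-methoxyethyl on an oxygen on a saturated carbon and the rest of the structure stays the same. Going by the values given here, the only step with a readable size is an at least 1.6-fold higher number from compound 1 to compound 2 (0.21 log units; that floor lies within the scatter) and it offers no firm change. Neither a step that the limit leaves unreadable from compound 1 to compound 3 nor a step that the two limits leave unreadable from compound 2 to compound 3 gives a size. Among the compounds with values here, none of the measured compounds carries the oxan-4-yl group, so the expectation rests on the high number of compound 1 at 135000 nM. The expectation also rests on the two limits of compound 2 and compound 3. The expected step is a step that the limit leaves unreadable from compound 3 to compound 4 and no change beyond the scatter is expected in this assay for this swap. The estimate for compound 4 is 150000 nM (expected range 60000 nM to 300000 nM).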

Compound 4, half-maximal cytotoxic concentration: > 100000 nM
Compound 4 was reported as a limit; the forecaster's own chance of this, stated with the estimate: 60%; the middle value does not contradict the limit.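

In this assay, the steps to compound 4 from compound 1, compound 2 and compound 3 cannot be read, because compound 4 rests on a limit: the limit of > 100000 nM in this assay, at which 2 of the 4 values shown sit.

The compounds shown leave open whether oxan-4-yl and 2-methoxyethyl differ at all in this test, and how far compound 2, compound 3 and compound 4 truly lie from compound 1.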